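Replacing a Carboxy Group in an AKT Inhibitor Series

This account rests on a few compounds, and the source may have more. Where it says the series, first, only, none or still open, it means among the compounds named here.

Measured compounds:
Compound 1, `Cn1ncc(Cl)c1-c1cc(C(=O)N[C@H]2CNCC[C@@H]2c2ccc(C(F)(F)F)cc2)oc1Cl`: 127 nM
Compound 2, `Cn1ncc(Cl)c1-c1cc(C(=O)N[C@@H]2CN[C@H](CC(=O)O)C[C@H]2c2ccc(Cl)c(Cl)c2)oc1Cl`: 1.94 nM
Compound 3, `Cn1ncc(Cl)c1-c1cc(C(=O)NC2CNCC2c2ccc(C(F)(F)F)cc2)oc1Cl`: 538 nM

In an assay for inhibition of RAC-alpha serine/threonine-protein kinase (Homo sapiens), read by HTRF, with a stated time of 1 h (a higher number here means a weaker inhibitor, a lower number a stronger inhibitor), compound 2 gives the lowest number of the three, and its gaps to compound 1 and to compound 3 both lie beyond the usual scatter of repeated measurements. Compounds 1 and 3 differ from compound 2 in more than one place, so neither of them isolates a single change.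

Compound 4, `COCC[C@@H]1C[C@@H](c2ccc(Cl)c(Cl)c2)[C@H](NC(=O)c2cc(-c3c(Cl)cnn3C)c(Cl)o2)CN1`, is yet to be measured. It differs from compound 2 in one place: methoxymethyl in place of carboxy on a saturated chain carbon bound to a saturated ring carbon. The carboxy group that leaves carries the only hydrogen-bond donor of that substituent; the methoxymethyl group that enters keeps one acceptor and no donor. Within the data shown here, no measured pair shows this change, so its effect is unknown from these data. The step from compound 2 to compound 4 is expected to be a modest loss, a 3.6-fold higher number from compound 2 to compound 4 (0.56 log units; beyond the scatter), though a result within the scatter is also possible. Compound 4 is therefore estimated at 7 nM in this assay, in the range 2 nM to 30 nM.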

Compound 4, half-maximal inhibitory concentration: 7.01 nM
Compound 4: the middle estimate sits 1.0-fold (0.00 log units) below what was measured; low and high end bracket the measured number.
By their numbers in this assay, from the lowest: compound 2; then compound 4; then compound 1; then compound 3.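

In this assay, among these compounds, the change from carboxy to methoxymethyl on a saturated chain carbon bound to a saturated ring carbon gives the first single-place step in this set: a modest loss, a 3.6-fold higher number from compound 2 to compound 4 (0.56 log units; beyond the scatter), which lies beyond the usual scatter. The carboxy group, and with it the hydrogen-bond donor of this substituent, can therefore be given up here at limited cost, since the acceptor-only methoxymethyl group still leaves compound 4 at 7.01 nM. No measurement offered here explains the size of this step.

The compounds shown leave open how other groups would fare at this place, such as a primary amide, a hydroxyl group at the end of the chain, or a longer ether chain. They also leave open whether the same step would hold on a different aryl group.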